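A Second Chloro on the Aryl Piperazine Tail

The source may hold more compounds than are shown below. What is called first, only, known or untested is meant among the compounds shown, and "the series" means these compounds.

Compound 1, `NC(=O)[C@@H]1CCCN1C(=O)CCCCCN1CCN(c2cccc(Cl)c2)CC1`, 478 nM
Compound 2, `NC(=O)[C@@H]1CCCN1C(=O)CCCCCN1CCN(c2cccc(Cl)c2Cl)CC1`, 179 nM
Compound 3, `NC(=O)[C@@H]1Cc2ccccc2CN1C(=O)CCCCCN1CCN(c2ccccc2Cl)CC1`, 393 nM

These values come from an assay on HEK293 cells for displacement of a labelled ligand from 5-hydroxytryptamine receptor 7 (Homo sapiens), with a stated time of 1 h; a lower number here means a stronger inhibitor, a higher number a weaker inhibitor. Compound 1 and compound 2 share one core, while compound 3 carries another; the difference between the two cores is not broken down here. From compound 1 to compound 2 the change is chloro in place of hydrogen on an aromatic carbon, which gave a 2.7-fold lower number from compound 1 to compound 2 (0.43 log units; beyond the scatter). Compound 4, `NC(=O)[C@@H]1Cc2ccccc2CN1C(=O)CCCCCN1CCN(c2cccc(Cl)c2Cl)CC1`, is not yet measured and differs from compound 3 by chloro in place of hydrogen on an aromatic carbon. This is the same kind of change, but the surroundings differ: in compound 2 the entering chloro is ortho to a large group, in compound 4 it is meta to a large group. Because of a 2.7-fold lower number from compound 1 to compound 2 (0.43 log units; beyond the scatter) the step expected in this assay is a 2.5-fold lower number from compound 3 to compound 4 (0.39 log units; beyond the scatter), with added uncertainty from the different surroundings. Compound 4 is therefore estimated at 160 nM, between 60 nM and 420 nM.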

Compound 4, inhibition constant: 95 nM
Compound 4: middle estimate off by 1.7-fold (0.23 log units), on the high side; measured number inside the range.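

In this assay, adding the chloro on the second core again lowered the number, giving a 4.1-fold lower number from compound 3 to compound 4 (0.62 log units; beyond the scatter). The sizes of the two steps cannot be told apart: the same change on two cores in this assay, a 2.7-fold lower number (0.43 log units; beyond the scatter) from compound 1 to compound 2 and a 4.1-fold lower number (0.62 log units; beyond the scatter) from compound 3 to compound 4, 1.5-fold (0.19 log units) apart, within the scatter of two such steps. The change therefore carried over from one core to the other in both direction and size, but two pairs cannot show that it would do so on any further core, and they do not explain why it lowers the number.

Going by these compounds, it remains open whether a methyl or a methoxy group in place of the entering chloro would give a similar step. It is also unknown whether the step would hold with a longer chain in the tail.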